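Swapping the Aryl Ring: From Compound 3 to Compound 4

This account rests on a few compounds, and the source may have more. Where it says the series, first, only, none or still open, it means among the compounds named here.

Of the compounds shown here, three sharing one core have been tested in a functional assay on MCF7 cells (Homo sapiens) for inhibition; a higher number here means a weaker inhibitor, a lower number a stronger inhibitor. Compound 1 `CC/C(=C(/c1ccc(/C=C/C(=O)O)cc1)c1cc2ccccc2[nH]1)c1ccccc1OC(F)(F)F` gives 206 nM, compound 2 `CC/C(=C(/c1ccc(/C=C/C(=O)O)cc1)c1cc2ccccc2[nH]1)c1ccc(OC)cc1` gives 61 nM, and compound 3 `CC/C(=C(/c1ccc(/C=C/C(=O)O)cc1)c1cc2ccccc2[nH]1)c1ccc(C(F)(F)F)cc1Cl` gives 27 nM. Compound 3 thus stands lowest of the three numbers, separated from the others by a 2.3-fold lower number from compound 2 to compound 3 (0.35 log units; beyond the scatter) and by a 7.6-fold lower number from compound 1 to compound 3 (0.88 log units; beyond the scatter). Compound 4 `CC/C(=C(/c1ccc(/C=C/C(=O)O)cc1)c1cc2ccccc2[nH]1)c1cc(Cl)ccc1Cl` differs from compound 3 in one place: 2,5-dichlorophenyl in place of 2-chloro-4-(trifluoromethyl)phenyl on a double-bonded chain carbon bound to a double-bonded chain carbon and a saturated chain carbon. Within the data shown here, no measured step matches this change directly; the aryl swaps seen so far, a 3.4-fold lower number from compound 1 to compound 2 (0.53 log units; beyond the scatter), a 7.6-fold lower number from compound 1 to compound 3 (0.88 log units; beyond the scatter) and a 2.3-fold lower number from compound 2 to compound 3 (0.35 log units; beyond the scatter), were all modest, and both steps ending at compound 3 favoured its ring. A modest rise in this assay is therefore expected for compound 4, amounting to a 1.9-fold higher number from compound 3 to compound 4 (0.27 log units; within the scatter). Compound 4 is estimated at 50 nM in this assay, within a range from 20 nM to 130 nM.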

Compound 4, half-maximal inhibitory concentration: 71 nM
Beside the measured number, compound 4's estimate is 1.4-fold (0.15 log units) below it, and the stated range covers the measured number.
By their numbers in this assay, from the lowest: compound 3; then compounds 2 and 4 (each within the scatter of the next); then compound 1.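

In this assay, the 2,5-dichlorophenyl ring does not hold the number set by the 2-chloro-4-(trifluoromethyl)phenyl ring (a 2.6-fold higher number from compound 3 to compound 4 (0.42 log units; beyond the scatter)). It cannot be told apart from the 4-methoxyphenyl ring (a 1.2-fold higher number from compound 2 to compound 4 (0.07 log units; within the scatter)) but still improves on the 2-(trifluoromethoxy)phenyl ring (a 2.9-fold lower number from compound 1 to compound 4 (0.46 log units; beyond the scatter)), so two chlorine-bearing rings at this position give different results. No supporting data explain these differences. As far as these compounds go, whether an amine or a nitrile on this ring would match compound 3 remains open, as does the effect of trifluoromethyl without chlorine.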